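This account rests on a few compounds, and the source may have more. Where it says the series, first, only, none or still open, it means among the compounds named here.

Measured compounds:
compound 1 `CNC(=O)C#Cc1ccc(NC(=O)Nc2ccc(Cl)c(C(F)(F)F)c2)cc1`, 23300 nM
compound 2 `CC(NC(=O)/C=C/c1ccc(NC(=O)Nc2cc(C(F)(F)F)ccc2Cl)cc1)c1ccccc1`, 35900 nM
compound 3 `CC(NC(=O)C#Cc1ccc(NC(=O)Nc2cc(C(F)(F)F)ccc2Cl)cc1)c1ccccc1`, 19000 nM

These numbers come from a functional assay on HepG2 cells (Homo sapiens) for inhibition, read by MTT assay, with a stated time of 120 h; on this read-out higher numbers stand for weaker inhibition and lower numbers for stronger inhibition. Compound 1 stands second highest of the three; compound 3 gives 19000 nM and compound 2 gives 35900 nM, and both lie within the usual scatter of the number for compound 1, so no order among the three can be claimed. Compound 4 `CNC(=O)c1cccc(-c2ccc(NC(=O)Nc3ccc(Cl)c(C(F)(F)F)c3)cc2)c1` has not been measured. It differs from compound 1 in one place: 3-(methylcarbamoyl)phenyl in place of 2-(methylcarbamoyl)ethynyl on an aromatic carbon. Within the data shown here, no step between measured compounds that differ in one place is available, so the expectation rests on this change alone. In this assay a small step toward a lower number is expected, not clearly beyond the scatter. The step this estimate means, a 1.6-fold lower number from compound 1 to compound 4 (0.19 log units; within the scatter), is expected to stay within that scatter. Compound 4 is estimated at 15000 nM, with a range from 5000 nM to 50000 nM.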

Compound 4, half-maximal inhibitory concentration: 37100 nM
The estimate for compound 4 lay 2.5-fold (0.39 log units) below the measured number; low and high end bracket the measured number.
By their numbers in this assay, from the lowest: compounds 3, 1, 2 and 4 (each within the scatter of the next).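

Putting 3-(methylcarbamoyl)phenyl in place of 2-(methylcarbamoyl)ethynyl on this aromatic carbon gives, in this assay, a 1.6-fold higher number from compound 1 to compound 4 (0.20 log units; within the scatter), so the change cannot be told from repeat scatter. Among these compounds, at this position, para to a large group, a side arm with an added aromatic ring therefore leaves the read-out without a readable shift, which the earlier compounds could not show. Nothing measured here offers an explanation for this result.

Still open, from the compounds shown here alone, is whether a carboxylic acid or an amine in place of the methylcarbamoyl group would move the number beyond the scatter.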